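A flexible aminohexyl chain in place of an aminophenyl group

The compounds below may be only part of what the source reports. "The series", "measured", "known", "first", "only" and "open" are said of these compounds alone.

In a functional assay on HCT-116 cells (Homo sapiens) for cytotoxicity, read by MTT assay, with a stated time of 72 h (a higher number here means a weaker inhibitor, a lower number a stronger inhibitor), compound 1 `Nc1cccc(Nc2c(C(=O)NCc3ccc(F)cc3)nc(Br)c3cccnc23)c1` gives only a limit, > 10000 nM, so its true potency is not known. Compound 2 `N[C@H]1CC[C@H](Nc2c(C(=O)NCc3ccc(F)cc3)nc(N3CCCCC3)c3cccnc23)CC1`, built on a differently decorated core, gives 8000 nM in this assay. Compound 3 `NCCCCCCNc1c(C(=O)NCc2ccc(F)cc2)nc(Br)c2cccnc12` differs from compound 1 in one place: 6-aminohexyl in place of 3-aminophenyl on a nitrogen on an aromatic ring. Among the compounds with values here, with compound 1 sitting at the limit of > 10000 nM in this assay, at which 1 of the 2 values shown sits, no measured step guides the change. Compound 3 is expected to remain weak, with the step that the limit leaves unreadable from compound 1 to compound 3 not beyond the scatter. The estimate for compound 3 is 12000 nM, between 3000 nM and 40000 nM.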

Compound 3, half-maximal inhibitory concentration: 7000 nM
Estimate against measurement, compound 3: 1.7-fold (0.23 log units) above; measured number inside the range.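

On the shared core, a 6-aminohexyl chain on this nitrogen gives a measurable number in this assay: compound 3 gives 7000 nM. As far as these compounds go, the value for compound 1 is only a limit, so the true size of the change stays unknown: the limit of > 10000 nM in this assay, at which 1 of the 3 values shown sits. The swap of ring for open chain reads as an at least 1.4-fold lower number from compound 1 to compound 3 (0.15 log units; that floor lies within the scatter), which shows no firm gain in potency.

From the compounds shown here alone, it remains open how a shorter chain such as 4-aminobutyl would read at this position. Going by these compounds, a chain ending in a carboxylic acid instead of an amine is equally open.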